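The source may report more compounds than this note shows. Statements on the series, on what has been measured and on what is new or still open speak of the compounds shown alone.

The measured compounds:
compound 1, `O=C1C(c2ccccc2Cl)CC(c2ccccc2Cl)C(=O)N1c1ccccc1`, gives 40.6% in a functional assay on the whole organism (strain Swiss albino) for inhibition, with Mus musculus as the target, in the maximal electroshock model, with a stated time of 2 h, at a dose of 25 mg/kg by the intraperitoneal route; a lower number here means less inhibition, a higher number more inhibition at the dose given (going by the name of the read-out);
compound 2, `NN1C(=O)C(c2ccccc2Cl)CC(c2ccccc2Cl)C1=O`, gives 73.3% in this assay.

Within the data shown here, compound 2 holds the higher of the two numbers; its only neighbour is compound 1, and the step of a number 32.7 percentage points higher from compound 1 to compound 2 (beyond the scatter) lies beyond the scatter. The unmeasured compound 3, `O=C1C(c2ccccc2Cl)CC(c2ccccc2Cl)C(=O)N1c1cccc(Cl)c1`, differs from compound 2 in one place: 3-chlorophenyl in place of amino on an amide-type nitrogen in a ring.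

Among the measured compounds shown here, only one measured step bears on this change, and it runs the other way: the step from compound 1 to compound 2, in which amino replaced phenyl, was a number 32.7 percentage points higher from compound 1 to compound 2 (beyond the scatter). Compound 3 carries a 3-chlorophenyl group where compound 2 carries amino, so the change from compound 2 to compound 3 largely undoes that step, with a chlorine added to the ring. A drop of roughly the same size is therefore expected, back toward the level of compound 1; the chlorine is an unknown, so the range is kept wide. In this assay compound 3 is estimated at 45%, between 25% and 65%, an expected step of a number 28.3 percentage points lower from compound 2 to compound 3 (beyond the scatter).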

Compound 3, a percentage reported as inhibition, in the whole organism at one dose (the size of the read-out at that dose, not a potency): 43.7%
Beside the measured number, compound 3's estimate is 1.3 percentage points above it; low and high end bracket the measured number.
By their numbers in this assay, from the lowest: compounds 1 and 3 (each within the scatter of the next); then compound 2.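

Putting 3-chlorophenyl in place of amino on the amide-type nitrogen in the ring gives a number 29.6 percentage points lower from compound 2 to compound 3 (beyond the scatter) in this assay, so now two compounds with an aromatic ring on this nitrogen, not just one, stand apart from the amino compound. Chloro in place of hydrogen on that aromatic ring gives a number 3.1 percentage points higher from compound 1 to compound 3 (within the scatter), which means compound 1 and compound 3 cannot be told apart in this read-out, and this chlorine makes no readable difference here. No measurement at hand explains why the amino compound differs from the two compounds with an aromatic ring on this nitrogen.

The compounds shown leave open whether the higher read-out belongs to amino itself or would also appear with another group on this nitrogen, such as methyl, hydroxyl or dimethylamino. They also leave open whether a different group on the aromatic ring, such as methoxy or a carboxylic acid, would separate from compound 1 in a way this chlorine does not.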